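The compounds below may be only part of what the source reports. "The series", "measured", "known", "first", "only" and "open" are said of these compounds alone.

Compound 2, with the structure `COc1ccc(F)cc1-c1cccc(-c2nn(CCCCF)c(=O)o2)c1`, gives 36% in a functional assay on the whole organism (strain Wistar albino) for inhibition, with Rattus norvegicus as the target, read by paw edema, with stated times of 30 min and 0.5 h, at a dose of 10 mg/kg by the oral route; a higher number here means more inhibition at the dose given (going by the name of the read-out), a lower number less inhibition. That is the highest of the three numbers measured. Its nearest neighbour is compound 3, `COc1ccc(F)cc1-c1cccc(-c2nn(CCO)c(=O)o2)c1`, which in this assay gives 28%; the two lie within the usual scatter of each other. The furthest is compound 1, `COc1ccc(F)cc1-c1cccc(-c2n[nH]c(=O)o2)c1`, which in this assay gives 25%, and that gap is beyond the scatter.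

Compound 4 is `COc1ccc(F)cc1-c1cccc(-c2nn(CCCN)c(=O)o2)c1`. It differs from compound 2 in one place: amino in place of fluoromethyl on a saturated chain carbon, three bonds along the chain from an aromatic nitrogen. Among the measured compounds shown here, two measured steps bear on this. The change from a hydrogen to a 4-fluorobutyl chain gave a number 11 percentage points higher from compound 1 to compound 2 (beyond the scatter). Exchanging the fluorine-bearing end of that chain for a hydroxy group gave a number 8 percentage points lower from compound 2 to compound 3 (within the scatter), a step that stays within the scatter. Putting an amino group in place of the fluoromethyl end is a change of the same kind, so the expected step in this assay is a number 6 percentage points lower from compound 2 to compound 4 (within the scatter), which is not expected to exceed the scatter. Compound 4 is therefore estimated to give 30% in this assay, expected to lie between 18% and 42%.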

Compound 4, a percentage reported as inhibition, in the whole organism at one dose (the size of the read-out at that dose, not a potency): 29%
Estimate against measurement, compound 4: 1 percentage points above; low and high end bracket the measured number.
By their numbers in this assay, from the lowest: compounds 1, 3, 4 and 2 (each within the scatter of the next, the first and the last beyond it).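

In this assay amino in place of fluoromethyl gives a number 7 percentage points lower from compound 2 to compound 4 (within the scatter) and aminomethyl in place of hydroxy gives a number 1 percentage points higher from compound 3 to compound 4 (within the scatter) so at this position the amino end cannot be told apart from the fluorine-bearing end or the hydroxy end. Starting from the bare nitrogen, 3-aminopropyl in place of hydrogen gives a number 4 percentage points higher from compound 1 to compound 4 (within the scatter) while 4-fluorobutyl gives a number 11 percentage points higher from compound 1 to compound 2 (beyond the scatter) so only 4-fluorobutyl stands clear of the scatter from hydrogen, with 2-hydroxyethyl and 3-aminopropyl both failing to do so. Nothing among the data shown gives a reason for these numbers.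

Compound 4 differs from compound 2 in both its chain end and its chain name, so a 4-aminobutyl chain would be needed to separate the two. As far as these compounds go, whether a carboxylic acid at the chain end or a dimethylamino end would move the number beyond the scatter also remains open.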